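The source may report more compounds than this note shows. Statements on the series, on what has been measured and on what is new or still open speak of the compounds shown alone.

Four compounds share one large framework and differ in two places. Compound 1 `CCC(C)n1ncn(-c2ccc(N3CCN(c4ccc(OC[C@@H]5CO[C@@](Cn6cncn6)(c6ccc(Cl)cc6Cl)O5)cn4)CC3)cc2)c1=O` and compound 3 `CCC(C)n1ncn(-c2ccc(N3CCN(c4ccc(OC[C@@H]5CO[C@@](Cn6cncn6)(c6ccc(Cl)cc6Cl)O5)cc4)CC3)nc2)c1=O` are built from the same atoms joined differently; the difference between the two cores is not broken down here. Compound 2 `CCC(C)n1ncn(-c2ccc(N3CCN(c4ccc(OC[C@@H]5CO[C@@](Cn6ccnc6)(c6ccc(Cl)cc6Cl)O5)cn4)CC3)cc2)c1=O` is made from compound 1, and compound 4 `CCC(C)n1ncn(-c2ccc(N3CCN(c4ccc(OC[C@@H]5CO[C@@](Cn6ccnc6)(c6ccc(Cl)cc6Cl)O5)cc4)CC3)nc2)c1=O` from compound 3, by the same change, which occurs twice among these compounds: 1H-imidazol-1-yl in place of 1H-1,2,4-triazol-1-yl on a saturated chain carbon bound to a saturated ring carbon and, in the core of compound 3, (1H-imidazol-1-yl in place of 1H-1,2,4-triazol-1-yl on a saturated chain carbon bound to a saturated ring carbon).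

In a physicochemical assay for solubility, read by HPLC, measured as thermodynamic solubility (on this read-out lower numbers stand for lower solubility and higher numbers for higher solubility), compound 1 gives 0.114 ug/mL, compound 2 gives 2.94 ug/mL and compound 3 gives 0.0539 ug/mL. Within the core of compound 1 the swap of the five-membered ring made a large step, a 26-fold higher number from compound 1 to compound 2 (1.41 log units; beyond the scatter). Compound 3 has the lowest number of the three measured compounds, and its gap to compound 1 is also beyond the scatter, so the core of compound 3 sits below the core of compound 1 in this assay.

Compound 4 has not yet been measured in this assay. The step of a 26-fold higher number from compound 3 to compound 4 (1.41 log units; beyond the scatter) is expected to be of a similar size because the same change within the core of compound 1 gave a 26-fold higher number from compound 1 to compound 2 (1.41 log units; beyond the scatter), although a single example is a thin basis. Starting from the low number of compound 3, compound 4 is therefore estimated at about 1.4 ug/mL, most likely between 0.4 ug/mL and 4.5 ug/mL.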

Compound 4, solubility: 7.99 ug/mL
For compound 4 the middle estimate is 5.7-fold (0.76 log units) below the measured one; measured number outside the range, above it.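

In this assay the swap of 1H-1,2,4-triazol-1-yl for 1H-imidazol-1-yl, on a saturated chain carbon bound to a saturated ring carbon, gives a 150-fold higher number from compound 3 to compound 4 (2.17 log units; beyond the scatter) and so points the same way as a 26-fold higher number from compound 1 to compound 2 (1.41 log units; beyond the scatter) in the core of compound 1. This shows that the direction of the step carried over from one core to the other, and that the step was large in both, but the printed sizes are not equal, with the larger one in the core of compound 3, so these two pairs give a shared direction and not a fixed amount that could simply be added to any core in the series. Nothing measured here explains why the numbers move in this way or why the two steps differ in size.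

The compounds shown leave open whether the same swap would point the same way in a third core, and how strongly the size of the step depends on the core that carries it. They also leave open how a 1H-pyrazol-1-yl group or a dimethylamino group would read in the same place, and whether either would stand closer to the triazole or to the imidazole compounds.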